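A few compounds are considered here, and "the series" means these few. Any claim that something is new, unique, unknown or untested is made for them only; others in the source may bear on it.

The three measured compounds share one core and differ only in the group on the carbonyl carbon of the amide. Compound 1 `CCC(=O)N1CCN(c2nc(=O)c3cc(C(F)(F)F)cc([N+](=O)[O-])c3s2)CC1` carries an ethyl group there, and in a physicochemical assay for solubility, read by HPLC (a higher number here means a more soluble compound, a lower number a less soluble compound), compound 1 gives 3.29 ug/mL. Compound 2 `CC(C)(C)C(=O)N1CCN(c2nc(=O)c3cc(C(F)(F)F)cc([N+](=O)[O-])c3s2)CC1` carries a tert-butyl group, and in this assay compound 2 gives 5.87 ug/mL. Compound 3 `O=C(C1CCCC1)N1CCN(c2nc(=O)c3cc(C(F)(F)F)cc([N+](=O)[O-])c3s2)CC1` carries a cyclopentyl group, and in this assay compound 3 gives 5.34 ug/mL, the second highest of the three numbers; its nearest neighbour is compound 2 and its furthest is compound 1, yet both gaps lie within the scatter, so the three cannot truly be placed in order. The steps read a 1.8-fold higher number from compound 1 to compound 2 (0.25 log units; within the scatter), a 1.6-fold higher number from compound 1 to compound 3 (0.21 log units; within the scatter) and a 1.1-fold lower number from compound 2 to compound 3 (0.04 log units; within the scatter). Compound 4 `O=C(C1CCC1)N1CCN(c2nc(=O)c3cc(C(F)(F)F)cc([N+](=O)[O-])c3s2)CC1` has not yet been measured; it differs from compound 3 as follows: cyclobutyl in place of cyclopentyl on a carbonyl carbon. Among the compounds with values here, the steps that bear on this change are the three exchanges of the group on the carbonyl carbon, and none of them left the scatter, so no step beyond the scatter is expected in this assay in either direction. Compound 4 is expected to give about 5 ug/mL in this assay, within a range from 2.5 ug/mL to 10 ug/mL. The expected step is a 1.1-fold lower number from compound 3 to compound 4 (0.03 log units; within the scatter).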

Compound 4, solubility: 39.3 ug/mL
Compound 4: middle estimate off by 7.9-fold (0.90 log units), on the low side; measured number above the stated range.
By their numbers in this assay, from the lowest: compounds 1, 3 and 2 (each within the scatter of the next); then compound 4.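

Within the data shown here, until this result, exchanging the group on the carbonyl carbon had never moved the number in this assay beyond the scatter, so this position looked insensitive among ethyl, tert-butyl and cyclopentyl. Cyclobutyl changes that picture: replacing the five-membered carbon ring with the four-membered one gives a 7.4-fold higher number from compound 3 to compound 4 (0.87 log units; beyond the scatter) and the position proves able to respond strongly, while the exchange from tert-butyl gives a 6.7-fold higher number from compound 2 to compound 4 (0.83 log units; beyond the scatter) and the exchange from ethyl gives a 12-fold higher number from compound 1 to compound 4 (1.08 log units; beyond the scatter) as the largest step in the set, so compound 4 stands apart from all three others, which remain within the scatter of one another. The compounds shown offer no measurement that accounts for this jump, and it cannot be tied to any feature of the cyclobutyl group.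

On these data alone, whether the high number belongs to cyclobutyl alone or extends to neighbouring groups such as cyclopropyl, isopropyl or an oxetane ring remains open. Also open, as far as these compounds go, is whether cyclobutyl on the same carbonyl carbon would give a similar step on a core carrying something other than the nitro group, such as a nitrile.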